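The compounds below may be only part of what the source reports. "The series", "measured", "known", "first", "only" and "open" are said of these compounds alone.

Compound 1, `CCC(COc1ccccc1Cl)OC(=O)NCc1ccccc1`, in an assay for inhibition of zeta-carotene desaturase, chloroplastic/chromoplastic (Capsicum annuum), using a Dixon plot, with a stated time of 8 h (a higher number here means a weaker inhibitor, a lower number a stronger inhibitor), gives a limit: > 100000 nM.
Compound 2, `CCC(COc1cccc(C#N)c1)OC(=O)NCc1ccccc1`, in this assay gives a limit: > 100000 nM.

Both values shown are limits, so that the step that the two limits leave unreadable from compound 1 to compound 2 cannot be read; this follows from the limit of > 100000 nM in this assay, at which 2 of the 2 values shown sit. Compound 2 therefore stands only at the limit, with no number of its own. Compound 3, `CCC(COc1cccc(Cl)c1Cl)OC(=O)NCc1ccccc1`, differs from compound 2 by 2,3-dichlorophenyl in place of 3-cyanophenyl on an oxygen on a saturated carbon. No measured step bears on this change, since the one step shown is unreadable. The expectation for compound 3 is therefore that it, too, gives no more than a limit in this assay, with the estimated step that the limit leaves unreadable from compound 2 to compound 3. Compound 3 is estimated at 150000 nM, between 40000 nM and 600000 nM.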

Compound 3, half-maximal inhibitory concentration: > 100000 nM
Compound 3: only a limit was reported (the forecaster's own chance of this, stated with the estimate: 80%); the middle value lies beyond the limit too.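

No new step can be read among compound 1, compound 2 and compound 3, because each gives only a limit: the limit of > 100000 nM in this assay, at which 3 of the 3 values shown sit.

The compounds shown leave open whether these three aromatic groups differ at all in this assay.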